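A few compounds are considered here, and "the series" means these few. Any claim that something is new, unique, unknown or untested is made for them only; others in the source may bear on it.

Compound 1, with the structure `COCCC1=C(N2CC2)C(=O)C(C)=C(N2CC2)C1=O`, is measured in a functional assay on L1210 cells (Mus musculus), with a stated time of 12 days (on this read-out higher numbers stand for higher potency (the scale is a negative logarithm) and lower numbers for lower potency), where compound 1 gives 5.42. Within the data shown here, its only measured companion is compound 2, of structure `CC1=C(N2CC2)C(=O)C(C2CCCCC2)=C(N2CC2)C1=O`, and in this assay compound 2 gives 5.39. Among the measured compounds shown here, the single measured step, a number 0.03 log units lower from compound 1 to compound 2 (within the scatter), is therefore no more than scatter, and compound 1 stands alongside compound 2 rather than apart from it; neither number can be placed above the other. Compound 3, of structure `CC1=C(N2CC2)C(=O)C(COc2ccccc2)=C(N2CC2)C1=O`, has not yet been measured. Compared with compound 1 it carries phenoxy in place of methoxymethyl on a saturated chain carbon bound to a double-bonded ring carbon. For the measured compounds named here, the one step that bears on this change is the exchange of the side chain between compound 1 and compound 2, which left the read-out in this assay unchanged within the scatter. Going by the values given here, since that is the only guide, a step of no real size is expected for compound 3 in this assay, and the estimated step is a number 0.03 log units higher from compound 1 to compound 3 (within the scatter). On this basis compound 3 is expected to give about 5.45 in this assay, with a range from 5 to 5.9.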

Compound 3, logarithm of the reciprocal of the active concentration, log(1/C): 4.71
The estimate for compound 3 lay 0.74 log units above the measured number; measured number outside the range, below it.
By their numbers in this assay, from the lowest: compound 3; then compounds 2 and 1 (each within the scatter of the next).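

The exchange of methoxymethyl for phenoxy on a saturated chain carbon bound to a double-bonded ring carbon gives, in this assay, a number 0.71 log units lower from compound 1 to compound 3 (beyond the scatter). The earlier pair showed only a number 0.03 log units lower from compound 1 to compound 2 (within the scatter), so a large change of side chain had left the read-out in place, and a change of side chain can now be seen to move it as well: the size of the group entering does not by itself settle the outcome, since cyclohexyl in compound 2 leaves the number within the scatter of compound 1 while phenoxy in compound 3 does not. No measurement given here offers an explanation for this drop.

The compounds shown leave open whether the lower number goes with the six-membered aromatic ring itself or with the greater length of the phenoxy side chain, a question that a cyclohexyloxy or a butoxy group at this place would address. They also leave open how a substituted phenoxy, such as 4-methoxyphenoxy, or an amine such as dimethylamino on the same chain carbon would read in this assay.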